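Homologating the Methyl of a Cyclic Ketone Scaffold

The source may report more compounds than this note shows. Statements on the series, on what has been measured and on what is new or still open speak of the compounds shown alone.

Measured compounds:
compound 1 `CC1(c2ccccc2)CC(=O)C(C2CC(c3ccc(OCc4ccc(C(F)(F)F)cc4)cc3)Cc3ccccc32)=C(O)O1` — > 10000 nM
compound 2 `COc1ccc(C2Cc3ccccc3C(C3=C(O)OC(C)(c4ccccc4)CC3=O)C2)cc1` — > 10000 nM

In a functional assay on SK-OV-3 cells (Homo sapiens) for inhibition, with a stated time of 72 h (a lower number here means a stronger inhibitor, a higher number a weaker inhibitor), compound 1 gives > 10000 nM, which is a limit of the assay and not a number. In this assay compound 2 likewise reaches only a limit, > 10000 nM. Among the compounds with values here, the one measured step, a step that the two limits leave unreadable from compound 1 to compound 2, removes the 4-(trifluoromethyl)phenyl group, yet its size cannot be read, since both ends sit at the same limit (the limit of > 10000 nM in this assay, at which 2 of the 2 values shown sit).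

Compound 3 `CCC1(c2ccccc2)CC(=O)C(C2CC(c3ccc(OCc4ccc(C(F)(F)F)cc4)cc3)Cc3ccccc32)=C(O)O1` differs from compound 1 by methyl in place of hydrogen on a saturated chain carbon bound to a saturated ring carbon. Within the data shown here, no measured step touches this part of the shared core, so nothing shows how the methyl addition would shift the read-out. With compound 1 standing at a limit in this assay, compound 3 is expected to remain there as well, the estimated step that the limit leaves unreadable from compound 1 to compound 3 being unreadable beyond the scatter. The estimate for compound 3 is therefore 15000 nM, within a range from 5000 nM to 50000 nM.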

Compound 3, half-maximal inhibitory concentration: > 10000 nM
Compound 3: only a limit was reported (the forecaster's own chance of this, stated with the estimate: 85%); the middle value does not contradict the limit.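

Within the data shown here, compound 1 and compound 3 both reach only a limit, not a number, so no step between them can be read: the limit of > 10000 nM in this assay, at which 3 of the 3 values shown sit.

The compounds shown leave open whether any change to the shared core would give a readable value in this assay at all.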